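The source may report more compounds than this note shows. Statements on the series, on what has been measured and on what is new or still open speak of the compounds shown alone.

Compounds measured in a functional assay on HeLa cells (Homo sapiens) for antiproliferative activity, read by sulforhodamine B assay, with a stated time of 72 h (on this read-out lower numbers stand for stronger inhibition and higher numbers for weaker inhibition), so far:
compound 1, `NC(=S)N/N=C/c1cc2ccccc2s1`, gives 6770 nM
compound 2, `N#Cc1ccc(NC(=S)N/N=C/c2ccc3ccccc3n2)cc1`, gives 20000 nM
compound 3, `FC(F)(F)c1ccc(NC(=S)N/N=C/c2ccc3ccccc3n2)cc1`, gives 59100 nM

Among these three, compound 2 holds the second highest number: compound 1 lies below it, and compound 3, the only one sharing its core and the substituted phenyl on the nitrogen, lies above it. For the measured compounds named here, the single one-place step recorded, a 3.0-fold higher number from compound 2 to compound 3 (0.47 log units; beyond the scatter), changed the group at the far end of that phenyl ring, and the number moved modestly upward.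

The next compound, compound 4, is `COc1ccccc1NC(=S)N/N=C/c1ccc2ccccc2n1`. It differs from compound 2 in one place: 2-methoxyphenyl in place of 4-cyanophenyl on an amide-type nitrogen. Going by the values given here, no measured step covers a methoxy group, or a group on this position of the phenyl ring, so the only guide is that swapping the substituent on this ring moved the number beyond the scatter but only modestly. A step of similar size, in either direction, is therefore the expectation, with no firm lean. The estimate for compound 4 in this assay is 15000 nM, within 5000 nM to 45000 nM, which corresponds to an expected step of a 1.3-fold lower number from compound 2 to compound 4 (0.12 log units; within the scatter).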

Compound 4, half-maximal inhibitory concentration: > 100000 nM
Compound 4 was reported as a limit; the forecaster's own chance of this, stated with the estimate: 10%; middle value at least 6.6-fold (0.82 log units) away from the limit.
By their numbers in this assay, from the lowest: compound 1; then compound 2; then compound 3. At a limit, above all of these: compound 4.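

In this assay compound 4 gives > 100000 nM, which is a limit of the assay and not a number: the limit of > 100000 nM in this assay, at which 1 of the 4 values shown sits.

Replacing 4-cyanophenyl with 2-methoxyphenyl on the amide-type nitrogen gives an at least 5.0-fold higher number from compound 2 to compound 4 (0.69 log units; beyond the scatter), so this position can tolerate less than the earlier pair suggested, and among the three compounds sharing this core, both changes away from 4-cyanophenyl raise the number. This change, however, swaps the substituent and also moves it to a different place on the phenyl ring, so the step alone cannot separate the effect of the methoxy group from the effect of where it sits.

A 4-methoxyphenyl group on this nitrogen would be needed to separate those two changes, and the compounds shown do not include one. Going by these compounds, it also remains open whether a plain phenyl ring, or a phenyl ring carrying an amine or a carboxylic acid, would give a number lower than, similar to or higher than that of compound 2.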